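A few compounds are considered here, and "the series" means these few. Any claim that something is new, unique, unknown or untested is made for them only; others in the source may bear on it.

Measured compounds:
Compound 1 `Cc1cccc(Cn2c(CN3CCN(C(=O)c4ccc(C(F)(F)F)cc4)CC3)nc3ccccc32)c1` gives 22.9% in an assay on isolated protein for inhibition of aldehyde dehydrogenase 1A1 (Homo sapiens), read by spectrophotometry, tested at 10 uM; on this read-out higher numbers stand for more inhibition at the one concentration tested (going by the name of the read-out) and lower numbers for less inhibition.
Compound 2 `O=C(C1CC1)N1CCN(Cc2nc3ccccc3n2Cc2ccccc2)CC1` gives 23.9% in this assay.
Compound 3 `CC(C)CCn1c(CN2CCN(C(=O)C3CC3)CC2)nc2ccccc21` gives 70% in this assay.

Compound 1 stands lowest of the three numbers. Compound 2 lies nearest to it, within the scatter, while compound 3 lies furthest, beyond the scatter. Going by the values given here, the only step between compounds differing in one place is a number 46.1 percentage points higher from compound 2 to compound 3 (beyond the scatter), and that step changes the group on the saturated chain carbon bound to the aromatic nitrogen, not the group on the carbonyl carbon.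

Compound 4 `Cc1cccc(Cn2c(CN3CCN(C(=O)C4CCC4)CC3)nc3ccccc32)c1` differs from compound 1 in one place: cyclobutyl in place of 4-(trifluoromethyl)phenyl on a carbonyl carbon. Among the compounds with values here, no measured step bears directly on this change. Compound 1 and compound 2 differ in two places, one of them being the group on the carbonyl carbon, and their values fall within the scatter of each other; this is the only indication available, and it points to a small effect of an exchange at the carbonyl carbon. Compound 4 is therefore expected to show a number 3.1 percentage points higher from compound 1 to compound 4 (within the scatter), a step not beyond the scatter in this assay. The estimate for compound 4 is 26%, with a range from 10% to 45%.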

Compound 4, a percentage reported as inhibition, at one concentration (the size of the read-out at that concentration, not a potency): 69.1%
For compound 4 the middle estimate is 43.1 percentage points below the measured one; measured number outside the range, above it.
By their numbers in this assay, from the lowest: compounds 1 and 2 (each within the scatter of the next); then compounds 4 and 3 (each within the scatter of the next).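

The group on the carbonyl carbon turns out to matter a great deal in this assay: with the rest of compound 1 unchanged, cyclobutyl in place of 4-(trifluoromethyl)phenyl gives a number 46.2 percentage points higher from compound 1 to compound 4 (beyond the scatter). Going by these compounds alone, until now, the only step in one place lay on the saturated chain carbon bound to the aromatic nitrogen, a number 46.1 percentage points higher from compound 2 to compound 3 (beyond the scatter), so this result adds a second site at which a single exchange moves the read-out beyond the scatter. Nothing shown accounts for the size of this step, and the exchange alters several things at once, replacing a six-membered aromatic ring carrying trifluoromethyl with a four-membered non-aromatic ring and going from 10 heavy atoms to 4, so no single feature can be singled out.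

The compounds shown leave open whether an unsubstituted phenyl, a cyclohexyl or a tert-butyl on the carbonyl carbon would behave like cyclobutyl or like 4-(trifluoromethyl)phenyl. They also leave open whether the exchange at the carbonyl carbon and the exchange on the chain carbon would add up in one compound, or whether a longer chain or a pyridine ring could be carried at either site.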